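A few compounds are considered here, and "the series" means these few. Any claim that something is new, unique, unknown or untested is made for them only; others in the source may bear on it.

Among the compounds with values here, compound 3 `CC(=O)c1ccc(-c2cn3ccnc3c(-c3ccc4ncn(C5CCCCC5)c4c3)n2)cc1` gives 12% in a functional assay on MCF7 cells (Homo sapiens) for inhibition, read by sulforhodamine B assay, with a stated time of 48 h, tested at 10 uM (on this read-out higher numbers stand for more inhibition at the one concentration tested (going by the name of the read-out) and lower numbers for less inhibition), the lowest of the three numbers so far: compound 1 `Brc1cn2ccnc2c(-c2ccc3ncn(C4CCCCC4)c3c2)n1` gives 47.6% and compound 2 `c1ccc(-c2cn3ccnc3c(-c3ccc4ncn(C5CCCCC5)c4c3)n2)cc1` gives 38%. Compound 4 `Brc1ccc(-c2cn3ccnc3c(-c3ccc4ncn(C5CCCCC5)c4c3)n2)cc1` differs from compound 3 by bromo in place of acetyl on an aromatic carbon. The step of a number 26 percentage points lower from compound 2 to compound 3 (beyond the scatter) is the closest guide, since removing the acetyl reverses it; the steps of a number 9.6 percentage points lower from compound 1 to compound 2 (within the scatter) and a number 35.6 percentage points lower from compound 1 to compound 3 (beyond the scatter) show that a bromo on the core and a phenyl sit within scatter of each other, while the acetylphenyl falls clearly lower. Within the data shown here, no measured pair shows bromo against hydrogen on the phenyl. The bromo in compound 4 is therefore expected to recover roughly the level of compound 2, with the step of a number 26 percentage points higher from compound 3 to compound 4 (beyond the scatter) expected. Compound 4 is estimated at 38%, in the range 20% to 55%.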

Compound 4, a percentage reported as inhibition, at one concentration (the size of the read-out at that concentration, not a potency): 46.4%
Estimate against measurement, compound 4: 8.4 percentage points below, within the range that was stated.
By their numbers in this assay, from the lowest: compound 3; then compounds 2, 4 and 1 (each within the scatter of the next).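

In this assay, the low number at this position goes with the acetyl and not with a substituent as such: a number 34.4 percentage points higher from compound 3 to compound 4 (beyond the scatter), while adding the bromo to the unsubstituted phenyl stays within the scatter, a number 8.4 percentage points higher from compound 2 to compound 4 (within the scatter). The 4-bromophenyl also remains level with the bromo on the shared core, a number 1.2 percentage points lower from compound 1 to compound 4 (within the scatter). No measurement at hand accounts for the gap between acetyl and bromo. Open, as far as these compounds go, is whether the low number belongs to the acetyl alone or extends to other groups at this position, such as an amine or a carboxylic acid.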